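Ketone aryl ring variation in a stilbene-chalcone series

The compounds below may be only part of what the source reports. "The series", "measured", "known", "first", "only" and "open" are said of these compounds alone.

Three measured compounds share one core and differ only on the aryl ring attached to the carbonyl. Compound 1, `COc1ccc(/C=C/c2cc(OC)cc(OC)c2/C=C/C(=O)c2ccccc2)cc1`, carries the unsubstituted ring; in a functional assay on A549 cells (Homo sapiens) for antiproliferative activity, read by MTT assay, with a stated time of 48 h (a lower number here means a stronger inhibitor, a higher number a weaker inhibitor), compound 1 gives 3.9 ug/mL. Compound 2, `CCCCCCOc1ccc(C(=O)/C=C/c2c(/C=C/c3ccc(OC)cc3)cc(OC)cc2OC)cc1`, adds a hexyloxy group, and in this assay compound 2 gives 8.4 ug/mL. Compound 3, `COc1ccc(/C=C/c2cc(OC)cc(OC)c2/C=C/C(=O)c2ccc(N)cc2)cc1`, carries an amino group, and in this assay compound 3 gives 3.8 ug/mL. Compound 3 holds the lowest number of the three, yet its separation from compound 1 is within the scatter, so no order between those two can be claimed; the only separation beyond the scatter is a 2.2-fold lower number from compound 2 to compound 3 (0.34 log units; beyond the scatter).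

Compound 4, `COc1ccc(/C=C/c2cc(OC)cc(OC)c2/C=C/C(=O)c2ccccc2C)cc1`, changes this ring once more: 2-methylphenyl in place of 4-aminophenyl on a carbonyl carbon. Going by the values given here, two measured steps bear on it. a 1.0-fold lower number from compound 1 to compound 3 (0.01 log units; within the scatter) shows that removing or adding the amino group alone leaves the number within the scatter. a 2.2-fold higher number from compound 1 to compound 2 (0.33 log units; beyond the scatter) shows that a hexyloxy substituent raises the number modestly. Among the compounds with values here, no measured step involves a methyl on this ring, so the expectation leans on compound 1 as the nearest reference, allowing for a modest drift toward higher numbers. In this assay compound 4 is expected near 4.8 ug/mL, with a range from 2.5 ug/mL to 9.5 ug/mL, meaning an expected step of a 1.3-fold higher number from compound 3 to compound 4 (0.10 log units; within the scatter) that is not expected to exceed the scatter.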

Compound 4, half-maximal inhibitory concentration: 5.9 ug/mL
Estimate against measurement, compound 4: 1.2-fold (0.09 log units) below, within the range that was stated.
By their numbers in this assay, from the lowest: compounds 3, 1, 4 and 2 (each within the scatter of the next, the first and the last beyond it).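

In this assay, a methyl group added to the unsubstituted ring gives a 1.5-fold higher number from compound 1 to compound 4 (0.18 log units; within the scatter) and so opens no readable separation from that ring, while the exchange of 4-aminophenyl for 2-methylphenyl on the carbonyl carbon gives a 1.6-fold higher number from compound 3 to compound 4 (0.19 log units; within the scatter) even though the hydrogen-bond donor and acceptor counted on the leaving group are gone. The ring on the carbonyl therefore accepts this methyl group, and the amino group can be absent, without any step beyond the scatter. Among the steps on this ring, only the two involving hexyloxy lie beyond the scatter, and no evidence on these compounds gives a reason for any of these numbers.

On these data alone, whether the hexyloxy result depends on chain length remains open, and a butoxy or octyloxy chain on the same ring would test that. A carboxylic acid or a nitrile on this ring would show whether groups unlike the amino, methyl and hexyloxy substituents move the number beyond the scatter.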